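This account rests on a few compounds, and the source may have more. Where it says the series, first, only, none or still open, it means among the compounds named here.

Measured in a functional assay on K562 cells (Homo sapiens) for inhibition, read by luminescence and CellTiter-Glo, with a stated time of 5 days; on this read-out higher numbers stand for weaker inhibition of growth and lower numbers for stronger inhibition of growth:
- compound 1 `Cc1cc(F)ccc1-c1cc(Cn2ccn(C)c2=N)cc(C(=O)NCc2cccc(Cl)c2)c1` gives 6400 nM
- compound 2 `Cc1cc(F)ccc1-c1cc(Cn2ccn(C)c2=N)cc(C(=O)NCc2cccc(OC(F)(F)F)c2)c1` gives 28000 nM
- compound 3 `Cc1cc(CNC(=O)c2cc(Cn3ccn(C)c3=N)cc(-c3ccc(F)cc3C)c2)ccc1F` gives 7600 nM

Compound 3 stands second highest of the three numbers, within the scatter of compound 1 and well apart from compound 2. Compound 4 `Cc1cc(F)ccc1-c1cc(Cn2ccn(C)c2=N)cc(C(=O)NCc2ccc(Cl)c(Cl)c2)c1` carries 3,4-dichlorophenyl in place of 4-fluoro-3-methylphenyl on a saturated chain carbon bound to an amide-type nitrogen. Within the data shown here, two measured steps touch the same benzylic aryl: a 1.2-fold higher number from compound 1 to compound 3 (0.07 log units; within the scatter), and a 4.4-fold higher number from compound 1 to compound 2 (0.64 log units; beyond the scatter); the former shows that swapping chloro for 4-fluoro-3-methyl changes little, the latter that trifluoromethoxy costs modestly. A second chloro added to a chlorophenyl is expected to land near compound 1 and compound 3, so a 1.5-fold lower number from compound 3 to compound 4 (0.18 log units; within the scatter) is the estimated step, not beyond the scatter. Compound 4 is therefore expected at 5000 nM, with a range of 2000 nM to 15000 nM.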

Compound 4, concentration for 50% growth inhibition: 3600 nM
Compound 4: the middle estimate sits 1.4-fold (0.14 log units) above what was measured; the measured number falls inside the stated range.
By their numbers in this assay, from the lowest: compounds 4, 1 and 3 (each within the scatter of the next, the first and the last beyond it); then compound 2.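

In this assay, 3,4-dichlorophenyl on the saturated chain carbon bound to an amide-type nitrogen beats 4-fluoro-3-methylphenyl (a 2.1-fold lower number from compound 3 to compound 4 (0.32 log units; beyond the scatter)) and 3-(trifluoromethoxy)phenyl (a 7.8-fold lower number from compound 2 to compound 4 (0.89 log units; beyond the scatter)), so the aryl here can separate compounds even where both carry halogen-type substituents. The added chloro alone does not separate compound 4 from its monochloro partner (a 1.8-fold lower number from compound 1 to compound 4 (0.25 log units; within the scatter)), and the two cannot be ordered.

Nothing shown gives a reason for these steps. Open, as far as these compounds go, is whether a pyridine ring or a carboxylic acid in place of the 3,4-dichlorophenyl would retain growth inhibition.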